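A few compounds are considered here, and "the series" means these few. Any claim that something is new, unique, unknown or untested is made for them only; others in the source may bear on it.

In a functional assay on MCF7 cells (Homo sapiens) for cytotoxicity (a higher number here means a weaker inhibitor, a lower number a stronger inhibitor), the three measured compounds show no separation. Compound 1 `Cc1c(-n2cc(C#N)c(=O)n(-c3ccccc3)/c2=N\c2ccccc2)c(=O)n(-c2ccccc2)n1C` gives 45000 nM, compound 2 `Cc1c(-n2cc(C#N)c(=O)n(-c3ccc(Br)cc3)c2=S)c(=O)n(-c2ccccc2)n1C` gives 43400 nM and compound 3 `Cc1c(-n2cc(C#N)c(=O)n(-c3ccccc3)c2=N)c(=O)n(-c2ccccc2)n1C` gives 54200 nM. Compound 2 stands within the scatter of both compound 1 and compound 3. Still unmeasured is compound 4 `Cc1c(-n2cc(C#N)c(=O)n(-c3ccc(I)cc3)c2=S)c(=O)n(-c2ccccc2)n1C`, which differs from compound 2 at one place: iodo in place of bromo on an aromatic carbon. Among the measured compounds shown here, no measured pair tests a change at this place, so there is no direct precedent. No step beyond the scatter is expected in this assay. The estimated step of a 1.1-fold lower number from compound 2 to compound 4 (0.04 log units; within the scatter) is small. Compound 4 is expected at 40000 nM, with an estimated range of 20000 nM to 75000 nM.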

Compound 4, half-maximal inhibitory concentration: 30700 nM
Compound 4: the middle estimate sits 1.3-fold (0.11 log units) above what was measured; the range from low to high includes it.
By their numbers in this assay, from the lowest: compounds 4, 2, 1 and 3 (each within the scatter of the next).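

In this assay, among the compounds shown here, the change from 4-bromophenyl to 4-iodophenyl gives the only single-place pair, with a 1.4-fold lower number from compound 2 to compound 4 (0.15 log units; within the scatter). At this place, on an aromatic carbon para to a large group, iodo and bromo therefore cannot be told apart in this read-out. Nothing available accounts for the size of this step. As far as these compounds go, how an amine or a carboxylic acid at this place would compare with bromo remains open. The separate contributions of the halogen and the thione or imine portion of the core also remain unresolved.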